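Ethyl for Chloro on the Anilide Ring of Compound 2

The compounds below may be only part of what the source reports. "The series", "measured", "known", "first", "only" and "open" are said of these compounds alone.

Measured so far:
compound 1, `O=C(CSc1nc(Nc2ccccc2)c2ccccc2n1)Nc1cccc(F)c1`, > 50000 nM in a functional assay on MDA-MB-231 cells (Homo sapiens) for inhibition, read by MTT assay, with a stated time of 72 h; a higher number here means a weaker inhibitor, a lower number a stronger inhibitor
compound 2, `O=C(CSc1nc(Nc2ccccc2)c2ccccc2n1)Nc1ccc(Cl)cc1`, 17200 nM in this assay

Compound 1 gives in this assay only a limit, > 50000 nM, and not a number; it is the line (the limit of > 50000 nM in this assay, at which 1 of the 2 values shown sits). Among the measured compounds shown here, compound 2 is the single compound with a numerical value, 17200 nM, and so it is the only point from which the next step can be judged. For the measured compounds named here, the one measured step, an at least 2.9-fold lower number from compound 1 to compound 2 (0.46 log units; beyond the scatter), changed the anilide ring in a different way from the step now at hand and only sets a lower bound for its size.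

Compound 3, `CCc1ccc(NC(=O)CSc2nc(Nc3ccccc3)c3ccccc3n2)cc1`, differs from compound 2 by ethyl in place of chloro on an aromatic carbon. Going by the values given here, no measured pair shows this exchange, so the expectation rests on compound 2 alone: a step of a 1.2-fold higher number from compound 2 to compound 3 (0.07 log units; within the scatter) is estimated, which is within the scatter, with no direction claimed. Compound 3 is therefore expected to give 20000 nM in this assay, with a range from 7000 nM to 50000 nM.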

Compound 3, half-maximal inhibitory concentration: 33900 nM
Estimate against measurement, compound 3: 1.7-fold (0.23 log units) below; the measured number falls inside the stated range.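

At the aromatic carbon para to a large group, ethyl, with its 2 carbon atoms, stands where compound 2 carries a single chlorine, and the result is a 2.0-fold higher number from compound 2 to compound 3 (0.29 log units; within the scatter). In this assay, compound 2 and compound 3 therefore cannot be told apart, so a numerical value at this place is not tied to chloro, as compound 2 alone could not show. Compound 1 remains a limit of the assay, so an at least 1.4-fold lower number from compound 1 to compound 3 (0.16 log units; that floor lies within the scatter) gives only a floor, and this step does not separate compound 3 from compound 1 in the way that an at least 2.9-fold lower number from compound 1 to compound 2 (0.46 log units; beyond the scatter) separates compound 2 from compound 1: the limit of > 50000 nM in this assay, at which 1 of the 3 values shown sits.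

The compounds shown leave open whether a longer chain such as butyl, an amine or a carboxylic acid on this same aromatic carbon would give a value set clearly apart from those of compound 2 and compound 3. They also leave open whether chloro or ethyl would give a numerical value at another place on the anilide ring.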